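Carboxymethoxy for amino on the indanone-type scaffold

A few compounds are considered here, and "the series" means these few. Any claim that something is new, unique, unknown or untested is made for them only; others in the source may bear on it.

The series is followed in a functional assay on Jurkat cells (Homo sapiens) for antiproliferative activity, read by MTT assay; on this read-out higher numbers stand for weaker inhibition and lower numbers for stronger inhibition. Compound 1 `COc1cc2c(cc1OC)C(=O)/C(=C/c1cccc(OC)c1OC)CC2` reaches only the limit > 50000 nM, which is a limit of the assay rather than a number. Compound 2 `COc1cc(/C=C2\Cc3cc(OC)c(OC)cc3C2=O)cc(OC)c1` gives 3000 nM. Compound 3 `COc1cc2c(cc1OC)C(=O)/C(=C/c1cc(C)c(N)c(C)c1)C2` gives 55 nM, the lowest of the two numbers recorded, well beyond the scatter from compound 2. Compound 4 `COc1cc2c(cc1OC)C(=O)/C(=C/c1cc(C)c(OCC(=O)O)c(C)c1)C2` is not yet measured; it differs from compound 3 by carboxymethoxy in place of amino on an aromatic carbon. For the measured compounds named here, no measured pair in this set isolates that change, so the expectation leans on the position of compound 3 alone. Compound 3 owes its standing to the amino group, and its replacement is expected to weaken inhibition, giving a step of a 36-fold higher number from compound 3 to compound 4 (1.56 log units; beyond the scatter) that lies beyond the scatter. Compound 4 is therefore estimated at 2000 nM, within 300 nM to 15000 nM.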

Compound 4, half-maximal inhibitory concentration: 6300 nM
Compound 4: middle estimate off by 3.2-fold (0.50 log units), on the low side; low and high end bracket the measured number.
By their numbers in this assay, from the lowest: compound 3; then compound 2; then compound 4. At a limit, above all of these: compound 1.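

In this assay, carboxymethoxy in place of amino on the aromatic carbon ortho to two methyl groups gives a 110-fold higher number from compound 3 to compound 4 (2.06 log units; beyond the scatter) and so shows that this position is highly sensitive to this change. Even so, compound 4 still gives a measured number, and the one value at a limit belongs to compound 1: the limit of > 50000 nM in this assay, at which 1 of the 4 values shown sits.

For the compounds shown here, the single step does not separate the loss of the amino group from the entry of the longer chain. As far as these compounds go, a hydroxyl, a methoxy, an acetamide or the methyl ester of the same chain at this position remains open.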